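A few compounds are considered here, and "the series" means these few. Any claim that something is new, unique, unknown or untested is made for them only; others in the source may bear on it.

Measured compounds in an ADME assay on THP-1 cells (Homo sapiens) for cytotoxicity; on this read-out lower numbers stand for stronger inhibition and higher numbers for weaker inhibition:
- compound 1 `COc1ccccc1-c1nnc(-c2ccc(C(=O)N/N=C/c3ccc([N+](=O)[O-])cc3)cc2)o1` gives 203000 nM
- compound 2 `COc1ccccc1-c1nnc(-c2ccc(C(=O)N/N=C/c3cccc(O)c3)cc2)o1` gives 398000 nM
- compound 3 `COc1ccccc1-c1nnc(-c2ccc(C(=O)N/N=C/c3cccc(F)c3)cc2)o1` gives 353000 nM

Compound 3 stands second highest of the three numbers. Its distances to the other two are small: a 1.1-fold lower number from compound 2 to compound 3 (0.05 log units; within the scatter) and a 1.7-fold higher number from compound 1 to compound 3 (0.24 log units; within the scatter) both lie within the scatter, so the three values read as one level rather than a spread.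

Compound 4 `COc1ccccc1-c1nnc(-c2ccc(C(=O)N/N=C/c3cccc([N+](=O)[O-])c3)cc2)o1` differs from compound 3 by nitro in place of fluoro on an aromatic carbon. For the measured compounds named here, two measured steps bear on this change. The step of a 1.7-fold higher number from compound 1 to compound 3 (0.24 log units; within the scatter) sets a nitro-bearing ring against the fluoro-bearing ring of compound 3, although the nitro there sits at a different position; the step of a 1.1-fold lower number from compound 2 to compound 3 (0.05 log units; within the scatter) shows that swapping the group at this position has so far moved nothing beyond the scatter. Going by the values given here, no measured step exchanges fluoro for nitro at the same place.

On this basis the step to compound 4 is expected to stay within the scatter, a 1.3-fold lower number from compound 3 to compound 4 (0.10 log units; within the scatter). Compound 4 is thus estimated at 280000 nM, with a range from 120000 nM to 650000 nM.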

Compound 4, half-maximal inhibitory concentration: 119000 nM
For compound 4 the middle estimate is 2.4-fold (0.37 log units) above the measured one; measured number outside the range, below it.
By their numbers in this assay, from the lowest: compounds 4, 1, 3 and 2 (each within the scatter of the next, the first and the last beyond it).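

In this assay the group at the position meta to a large group now makes a difference beyond the scatter: nitro in place of fluoro gives a 3.0-fold lower number from compound 3 to compound 4 (0.47 log units; beyond the scatter) and nitro in place of hydroxy gives a 3.3-fold lower number from compound 2 to compound 4 (0.52 log units; beyond the scatter), whereas fluoro and hydroxy had stayed within the scatter of each other. The nitro group's position gives a smaller step, a 1.7-fold lower number from compound 1 to compound 4 (0.23 log units; within the scatter), and compound 1 stays within the scatter of compound 2 and compound 3, so the two nitro compounds do not form a clearly separate level. No data at hand bear on the reason for these steps.

Open, going by these compounds, is whether an amine, a carboxylic acid or a nitrile at this place would track with nitro or with fluoro and hydroxy. Also open, on these data alone, is whether 4-fluorophenyl or 4-hydroxyphenyl would match its 3-substituted counterpart.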